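A few compounds are considered here, and "the series" means these few. Any claim that something is new, unique, unknown or untested is made for them only; others in the source may bear on it.

Measured compounds:
Compound 1, `Nc1scc(CN2CCN(c3cccc(Cl)c3Cl)CC2)c1C(=O)c1ccc(Cl)cc1`, gives 3.2% in a functional assay on CHO cells with adenosine receptor A1 (Homo sapiens) as the target, read by cAMP accumulation and immunoassay, with a stated time of 6 min, tested at 0.1 uM; on this read-out lower numbers stand for a stronger effect and higher numbers for a weaker effect at the one concentration tested.
Compound 2, `Nc1scc(CN2CCN(c3cccc(C(F)(F)F)c3)CC2)c1C(=O)c1ccc(Cl)cc1`, gives -30%.
Compound 3, `Nc1scc(CN2CCN(c3ccccc3C(F)(F)F)CC2)c1C(=O)c1ccc(Cl)cc1`, gives -7.5%.

Compound 3 stands second highest of the three, above compound 2 and below compound 1. Compound 4, `Nc1scc(CN2CCN(c3cccnc3)CC2)c1C(=O)c1ccc(Cl)cc1`, differs from compound 3 at the same place where the three measured compounds differ from one another: pyridin-3-yl in place of 2-(trifluoromethyl)phenyl on an amine nitrogen in a ring. Going by the values given here, two steps bear on this change, a number 10.7 percentage points lower from compound 1 to compound 3 (beyond the scatter) and a number 22.5 percentage points higher from compound 2 to compound 3 (beyond the scatter); both swap the aryl group on the ring nitrogen and both move the read-out by a modest amount, in either direction. For compound 4 a step of similar, modest size is therefore expected, with the direction uncertain, so the estimate is a number 2.5 percentage points lower from compound 3 to compound 4 (within the scatter). Compound 4 is thus expected to give about -10%, within a range from -35% to 12%.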

Compound 4, a percentage reported as activity, at one concentration (the size of the read-out at that concentration, not a potency): 3.4%
Compound 4: the middle estimate sits 13.4 percentage points below what was measured, within the range that was stated.
By their numbers in this assay, from the lowest: compound 2; then compound 3; then compounds 1 and 4 (each within the scatter of the next).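

In this assay, going by these compounds alone, pyridin-3-yl, the first group here with a hetero atom in its aromatic ring, gives a weaker effect than both trifluoromethyl-bearing groups: a number 10.9 percentage points higher from compound 3 to compound 4 (beyond the scatter) and a number 33.4 percentage points higher from compound 2 to compound 4 (beyond the scatter). Against 2,3-dichlorophenyl it shows no real change, with a number 0.2 percentage points higher from compound 1 to compound 4 (within the scatter), so a group with fewer heavy atoms and a hydrogen-bond acceptor can read the same as that larger group. Nothing measured here explains these steps.

The compounds shown leave open how pyridin-2-yl, pyridin-4-yl or a plain ethyl group on this ring nitrogen would read. They also leave open whether these steps would hold on another core.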